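The source may hold more compounds than are shown below. What is called first, only, known or untested is meant among the compounds shown, and "the series" means these compounds.

In a functional assay on BT-474 cells (Homo sapiens) for inhibition, read by CellTiter-Glo, with a stated time of 72 h (on this read-out higher numbers stand for weaker inhibition and lower numbers for stronger inhibition), compound 2 `Cc1cc(Nc2ncnc3cc(O)c(NC(=O)/C=C/[C@H]4CCCN4C)cc23)ccc1Oc1ccn2ncnc2c1` gives 2.4 nM, the lowest of the three numbers, although its gaps to the others lie within the scatter: compound 1 `Cc1cc(Nc2ncnc3cc(O)c(NC(=O)/C=C/[C@H]4CCCN4C)cc23)ccc1Oc1cnc2ccnn2c1` gives 3.11 nM and compound 3 `C=CC(=O)Nc1cc2c(Nc3ccc(Oc4cc5nncn5cn4)c(C)c3)ncnc2cc1OCC` gives 4.69 nM. Compound 4 `Cc1cc(Nc2ncnc3cc(O)c(NC(=O)/C=C/[C@H]4CCCN4C)cc23)ccc1Oc1cc2nccn2cn1` has the same atoms as compound 2, joined differently: a group of 9 heavy atoms (6 carbon, 3 nitrogen; one five-membered aromatic ring with 2 hetero atoms, one six-membered aromatic ring with 2 hetero atoms) in place of a group of 9 heavy atoms (6 carbon, 3 nitrogen; one five-membered aromatic ring with 3 hetero atoms, one six-membered aromatic ring with 1 hetero atom), on an oxygen on an aromatic ring. Going by the values given here, the one measured step bearing on this is the exchange of two such groups, a 1.3-fold lower number from compound 1 to compound 2 (0.11 log units; within the scatter), which stayed within the scatter. Among the compounds with values here, the group entering compound 4 has the same ring counts as the one in compound 1, so no change beyond the scatter is expected in this assay. The expected step is a 1.5-fold higher number from compound 2 to compound 4 (0.16 log units; within the scatter). The estimated value for compound 4 is 3.5 nM, with a range of 1.5 nM to 9 nM.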

Compound 4, half-maximal inhibitory concentration: 5.59 nM
For compound 4 the middle estimate is 1.6-fold (0.20 log units) below the measured one; the range from low to high includes it.
By their numbers in this assay, from the lowest: compounds 2, 1, 3 and 4 (each within the scatter of the next, the first and the last beyond it).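

On the oxygen on an aromatic ring, exchanging one of these isomeric groups for another now gives a step beyond the scatter in this assay (a 2.3-fold higher number from compound 2 to compound 4 (0.37 log units; beyond the scatter)), though a modest one. The other exchange involving compound 4 stays within the scatter (a 1.8-fold higher number from compound 1 to compound 4 (0.25 log units; within the scatter)), so the arrangement of atoms in the group can register here, but only slightly. Nothing available accounts for the step. On these data alone, whether a single-ring group such as pyridine or plain phenyl keeps numbers in this range remains open, as does whether the same exchange behaves alike on the core of compound 3.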